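Swapping a Chlorophenyl Arm for a Hydroxyphenyl Arm

The source may report more compounds than this note shows. Statements on the series, on what has been measured and on what is new or still open speak of the compounds shown alone.

Measured so far:
- compound 1, `COc1ccc(/C=C2\CCC/C(=C\c3cccc(OC)c3OC)C2=O)cc1`, with 43500 nM in an ADME assay on NHDF cells (Homo sapiens) for cytotoxicity, read by MTT assay, with a stated time of 72 h; on this read-out lower numbers stand for stronger inhibition and higher numbers for weaker inhibition
- compound 2, `COc1ccc(/C=C2\CCC/C(=C\c3cccc(Cl)c3)C2=O)cc1OC`, with 11900 nM in this assay

Compound 2 has the lowest of the two numbers measured in this assay, which on this read-out means the stronger effect on the cells. Compound 1 sits at a higher number, and the gap between the two lies beyond the usual scatter, so compound 2 is the more cytotoxic of the pair.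

Compound 3, `COc1ccc(/C=C2\CCC/C(=C\c3ccc(O)cc3)C2=O)cc1OC`, has not yet been measured. It differs from compound 2 in one place: 4-hydroxyphenyl in place of 3-chlorophenyl on a double-bonded chain carbon bound to a double-bonded ring carbon. Within the data shown here, no step between measured compounds matches this change, so there is nothing to copy from; the change is judged only on its own terms and on the spread between compound 1 and compound 2.

A modest move toward a higher number, a weaker effect, is expected, and the size of the step from compound 2 to compound 3 is estimated as a 1.7-fold higher number from compound 2 to compound 3 (0.23 log units; within the scatter). Compound 3 is therefore expected to give about 20000 nM in this assay, with a likely range from 8000 nM to 60000 nM.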

Compound 3, half-maximal inhibitory concentration: 26100 nM
Estimate against measurement, compound 3: 1.3-fold (0.12 log units) below; measured number inside the range.
By their numbers in this assay, from the lowest: compound 2; then compounds 3 and 1 (each within the scatter of the next).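

In this assay, putting 4-hydroxyphenyl in place of 3-chlorophenyl on a double-bonded chain carbon bound to a double-bonded ring carbon gives a 2.2-fold higher number from compound 2 to compound 3 (0.34 log units; beyond the scatter). Compound 1 and compound 2 differ in more than one place, so their gap could not be tied to any single group, whereas this pair differs in one place and the shift can be assigned to this swap alone. It shows that the number responds to what this arm carries, although the step is modest, and nothing available here speaks to the cause of the shift.

The swap changes the atom on the aromatic ring and its place on that ring at once, as the names 3-chlorophenyl and 4-hydroxyphenyl show, so the compounds shown cannot separate those two changes. Also open, from the compounds shown here alone, is how the number would respond to an amine or a carboxylic acid on this arm in place of the hydroxyl, and whether the same swap would give a step of similar size on a different arm of the shared core.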